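Nitro versus nitrile anilides with a para-substituted arylsulfonyl arm

The source may hold more compounds than are shown below. What is called first, only, known or untested is meant among the compounds shown, and "the series" means these compounds.

Measured compounds:
compound 1, `CC(CS(O)(O)c1ccc(F)cc1)C(=O)Nc1ccc(C#N)cc1C(F)(F)F`, 138000 nM
compound 2, `CC(CS(=O)(=O)c1ccc(C(F)(F)F)cc1)C(=O)Nc1ccc(C#N)cc1C(F)(F)F`, 28800 nM
compound 3, `CC(CS(=O)(=O)c1ccc(F)cc1)C(=O)Nc1ccc([N+](=O)[O-])cc1C(F)(F)F`, 4050 nM

All three were tested in a functional assay on LNCaP cells (Homo sapiens) for antiproliferative activity, read by MTT assay, with a stated time of 96 h; a lower number here means a stronger inhibitor, a higher number a weaker inhibitor. Compound 3 gives the lowest number of the three in this assay; its nearest neighbour on the numbers is compound 2, which lies beyond the scatter above it, and compound 1 lies further still. Compound 1 and compound 2 differ from compound 3 in more than one place, so no single-point step can be read from the measured set.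

Compound 4, `CC(CS(=O)(=O)c1ccc(C(F)(F)F)cc1)C(=O)Nc1ccc([N+](=O)[O-])cc1C(F)(F)F`, is not yet measured. It differs from compound 3 in one place: trifluoromethyl in place of fluoro on an aromatic carbon. The measured compounds carry both groups on this ring but never with the rest of the molecule held fixed, so the size of this step has to be guessed rather than read. The expectation is a small step from compound 3 to compound 4 in this assay, most likely none beyond the scatter, with a slight lean toward a higher number, a 1.2-fold higher number from compound 3 to compound 4 (0.09 log units; within the scatter). On that basis compound 4 is estimated at 5000 nM in this assay, with a plausible range from 1500 nM to 16000 nM.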

Compound 4, half-maximal inhibitory concentration: 26300 nM
For compound 4 the middle estimate is 5.3-fold (0.72 log units) below the measured one, outside the stated range (above it).
By their numbers in this assay, from the lowest: compound 3; then compounds 4 and 2 (each within the scatter of the next); then compound 1.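

In this assay, going by these compounds alone, with the nitro anilide held fixed, the aromatic carbon para to a large group responds to the change of substituent: trifluoromethyl in place of fluoro gives a 6.5-fold higher number from compound 3 to compound 4 (0.81 log units; beyond the scatter), a size that the earlier compounds could not provide. With trifluoromethyl held on that ring, nitro in place of cyano gives a 1.1-fold lower number from compound 2 to compound 4 (0.04 log units; within the scatter), so this pair does not separate the two anilide groups, and the gain seen with compound 3 is tied to fluoro on the ring in the nitro setting. Nothing available here bears on the reason for either step.

The compounds shown leave open whether the fluoro to trifluoromethyl step has the same size when a nitrile replaces the nitro group, since a single pair gives this step and only in the nitro series. Also open, going by these compounds, is how other groups on that aromatic carbon, such as chloro, methoxy or an amine, would compare with fluoro and trifluoromethyl, and whether a carboxylic acid in place of the nitro group would be tolerated.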